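Dropping the Amide Methyl of Compound 1

This account rests on a few compounds, and the source may have more. Where it says the series, first, only, none or still open, it means among the compounds named here.

Compound 1 `CCC1C(=O)N(C)c2cnc(-n3ccc4cc(C(=O)NC)ccc43)nc2N1c1ccn(C)n1` was tested in a functional assay on K562 cells (Homo sapiens) for antiproliferative activity, read by CCK-8 assay, with a stated time of 72 h (on this read-out higher numbers stand for weaker inhibition of growth and lower numbers for stronger inhibition of growth), where compound 1 gives 13300 nM. Of the two measured compounds it holds the higher number: compound 2 `CC[C@@H]1C(=O)N(C)c2cnc(Nc3ccc(S(=O)(=O)NCCO)cc3)nc2N1C1CCCC1`, which shares the core, gives 546 nM in this assay, a clearly lower value, so compound 1 is the weaker inhibitor of the pair. Compound 3 `CCC1C(=O)N(C)c2cnc(-n3ccc4cc(C(N)=O)ccc43)nc2N1c1ccn(C)n1` has not yet been measured. It differs from compound 1 in one place: hydrogen in place of methyl on an amide-type nitrogen. Among the measured compounds shown here, no measured pair shows the effect of this change, so the expectation rests on compound 1 alone. Because compound 1 gives 13300 nM, compound 3 is expected to land close to it, and the step of a 1.2-fold lower number from compound 1 to compound 3 (0.08 log units; within the scatter) is expected to be small, not beyond the usual scatter, in either direction. The estimate for compound 3 is 11000 nM, with a range from 4000 nM to 30000 nM.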

Compound 3, concentration for 50% growth inhibition: 31300 nM
Compound 3: the middle estimate sits 2.8-fold (0.45 log units) below what was measured; the measured number lies above the stated range.
By their numbers in this assay, from the lowest: compound 2; then compound 1; then compound 3.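

In this assay, cutting methylcarbamoyl back to carbamoyl gives a 2.4-fold higher number from compound 1 to compound 3 (0.37 log units; beyond the scatter), a modest weakening of growth inhibition. Among the compounds shown here, this is the first reading at this amide-type nitrogen, and it shows that the position responds to the loss of a single carbon atom, with methyl the better of the two substituents seen there. The data shown offer no explanation for this shift.

Going by these compounds, whether a longer chain on this nitrogen, such as ethyl or propyl, or a ring such as cyclopropyl, would lower the number further remains open. On these data alone, it is also open whether a carboxylic acid or a nitrile in place of the whole amide would retain growth inhibition, and whether removing this methyl would cost as much on a different core.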